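Removing a Carbonyl from the Piperidine Ring of Compound 2

The source may report more compounds than this note shows. Statements on the series, on what has been measured and on what is new or still open speak of the compounds shown alone.

Measured so far:
compound 1, `CC(C)CNC(=O)n1c(=O)oc2c(C3CCN(C)CC3)cccc21`, 535 nM
compound 2, `CN1CCC(c2ccc3c(c2)oc(=O)n3C(=O)NCCCCc2ccccc2)CC1=O`, 105 nM
compound 3, `COCCCNC(=O)n1c(=O)oc2cc(-c3ccc(F)cc3)ccc21`, 2600 nM

All three compounds were tested in an assay on HEK293 cells for inhibition of acid ceramidase (Homo sapiens), read by fluorescence, with stated times of 10 min and 3 h; a lower number here means a stronger inhibitor, a higher number a weaker inhibitor. Among them, compound 2 has the lowest number, so it is the strongest inhibitor of the three. The nearest is compound 1 with 535 nM, a gap beyond the usual scatter, and the furthest is compound 3 with 2600 nM. Compound 1 already carries a 1-methylpiperidin-4-yl group on its core, though its other parts differ from compound 2, so its value alone does not tell what that group does on the core of compound 2.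

The next compound, compound 4, `CN1CCC(c2ccc3c(c2)oc(=O)n3C(=O)NCCCCc2ccccc2)CC1`, differs from compound 2 in one place only:

1-methylpiperidin-4-yl in place of 1-methyl-2-oxopiperidin-4-yl on an aromatic carbon

Among the measured compounds shown here, no measured pair shows this change in isolation, so its size must be guessed. The rest of compound 2, including the 4-phenylbutyl chain on the amide, is kept. The step from compound 2 to compound 4 is expected to be small, probably within the scatter, with perhaps a slight weakening; the estimate is a 1.5-fold higher number from compound 2 to compound 4 (0.18 log units; within the scatter). Compound 4 is therefore estimated at 160 nM, with a range from 50 nM to 500 nM.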

Compound 4, half-maximal inhibitory concentration: 129 nM
Compound 4: middle estimate off by 1.2-fold (0.09 log units), on the high side; the measured number falls inside the stated range.
By their numbers in this assay, from the lowest: compounds 2 and 4 (each within the scatter of the next); then compound 1; then compound 3.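

In this assay, removing the ring carbonyl from the 1-methyl-2-oxopiperidin-4-yl group gives a 1.2-fold higher number from compound 2 to compound 4 (0.09 log units; within the scatter) and so leaves the two compounds indistinguishable. Among the compounds shown here, this is the first pair to isolate this change, with the 4-phenylbutyl chain and the shared core held constant, and it shows that on this aromatic carbon the six-membered ring can carry the carbonyl or lack it without a step beyond the scatter. No measurement among the data here explains why the carbonyl makes so little difference.

The compounds shown leave open which remaining parts of this ring matter: a piperidin-4-yl group, with a hydrogen in place of the methyl on the ring nitrogen, would test the methyl, and a tetrahydropyran-4-yl or cyclohexyl ring would test the nitrogen itself. They also leave open whether the carbonyl would be equally dispensable with a shorter chain on the amide, such as butyl or propyl, in place of 4-phenylbutyl.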